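Benzoyl substituent change on the dimethoxy core

A few compounds are considered here, and "the series" means these few. Any claim that something is new, unique, unknown or untested is made for them only; others in the source may bear on it.

Compound 1 `COc1cc2ncnc(NNC(=S)NC(=O)c3ccccc3F)c2cc1OC` gives 12700 nM in a functional assay on CNE-2 cells (Homo sapiens) for cytotoxicity, read by MTT assay, with a stated time of 72 h; on this read-out lower numbers stand for stronger inhibition and higher numbers for weaker inhibition. Among the three measured compounds it has the second highest number: compound 2 `COc1ccccc1C(=O)NC(=S)NNc1ncnc2ccccc12` at 15700 nM lies within the scatter of it, while compound 3 `O=C(NC(=S)NNc1ncnc2ccccc12)c1ccccc1` at 1490 nM is well below it. Compound 4 `COc1cc2ncnc(NNC(=S)NC(=O)c3ccc(C(F)(F)F)cc3)c2cc1OC` differs from compound 1 by 4-(trifluoromethyl)phenyl in place of 2-fluorophenyl on a carbonyl carbon. Within the data shown here, the only measured step on the benzoyl ring is an 11-fold lower number from compound 2 to compound 3 (1.02 log units; beyond the scatter), a different change in a different place, so no direct precedent exists for swapping one fluoro substituent for a trifluoromethyl group. A step of a 1.4-fold lower number from compound 1 to compound 4 (0.15 log units; within the scatter) is therefore expected, without a clear direction beyond the scatter. Compound 4 is estimated at 9000 nM, within 2500 nM to 32000 nM.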

Compound 4, half-maximal inhibitory concentration: 16500 nM
Beside the measured number, compound 4's estimate is 1.8-fold (0.26 log units) below it; the range from low to high includes it.
By their numbers in this assay, from the lowest: compound 3; then compounds 1, 2 and 4 (each within the scatter of the next).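

In this assay, 4-(trifluoromethyl)phenyl in place of 2-fluorophenyl on the carbonyl carbon gives a 1.3-fold higher number from compound 1 to compound 4 (0.11 log units; within the scatter) and so shows that, on the core of compound 1, this exchange does not move the number beyond the scatter. The exchange alters the substituent and its ring position together, so neither contribution can be read alone. No measurement on hand gives a reason for this result.

Going by these compounds, whether an unsubstituted phenyl would lower the number on this core, as in an 11-fold lower number from compound 2 to compound 3 (1.02 log units; beyond the scatter) on the core of compound 3, stays open. An amine or a carboxylic acid on this ring also remains untested in the compounds shown.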